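A few compounds are considered here, and "the series" means these few. Any claim that something is new, unique, unknown or untested is made for them only; others in the source may bear on it.

Measured compounds:
compound 1, `CC1=C(C(=O)OC(C)(C)C)C(c2ccoc2)NC(=O)N1`: 2%
compound 2, `CC1=C(C(=O)OCc2ccccc2)C(c2ccoc2)NC(=O)N1`: 1%
compound 3, `CC1=C(C(=O)OC(C)(C)C)C(c2ccsc2)NC(=S)N1`: 16%

Of the compounds shown here, three have been tested in an assay on membranes from HeLa cells for displacement of a labelled ligand from adenosine receptor A3 (Homo sapiens), read by scintillation counting, with a stated time of 180 min, tested at 1 uM; a lower number here means less inhibition, a higher number more inhibition at the concentration tested (going by the name of the read-out). Compound 1 gives 2% in this assay, and compound 2 gives 1%. The two differ in one place, (benzyl in place of tert-butyl on an oxygen next to a carbonyl group), and the measured step is a number 1 percentage points lower from compound 1 to compound 2 (within the scatter), so the change leaves the read-out essentially where it was. Compound 3 gives 16% in this assay, the highest of the three numbers and beyond the scatter from both others. The difference between the core of compound 3 and the core of compound 1 is not broken down here.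

Compound 4, `CC1=C(C(=O)OCc2ccccc2)C(c2ccsc2)NC(=S)N1`, has not yet been measured. It comes from compound 3 by benzyl in place of tert-butyl on an oxygen next to a carbonyl group, the same change already seen between compound 1 and compound 2. Beside the measured a number 1 percentage points lower from compound 1 to compound 2 (within the scatter), the expected step is a number 2 percentage points lower from compound 3 to compound 4 (within the scatter), because a number 1 percentage points lower from compound 1 to compound 2 (within the scatter) lies within the scatter and the same change on a new core gives no reason to expect more. In this assay compound 4 is therefore estimated at 14%, most likely between 3% and 27%.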

Compound 4, a percentage reported as inhibition, at one concentration (the size of the read-out at that concentration, not a potency): 2%
Compound 4: the middle estimate sits 12 percentage points above what was measured; the whole stated range lies above it.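

Putting benzyl in place of tert-butyl on an oxygen next to a carbonyl group gives, in this assay, a number 14 percentage points lower from compound 3 to compound 4 (beyond the scatter). Set beside the same change on the other core, this larger step cannot be called different from the earlier one: the same change on two cores in this assay, a number 1 percentage points lower (within the scatter) from compound 1 to compound 2 and a number 14 percentage points lower (beyond the scatter) from compound 3 to compound 4, 13 percentage points apart, within the scatter of two such steps. The pairs therefore give no firm sign that the core alters what this change does, but two pairs, each read at a single concentration, do not show that the change carries over unaltered either, and they say nothing about potency.

The compounds shown leave open how a small ethyl group, a longer chain or a chain bearing an amine would behave on that oxygen in place of tert-butyl or benzyl. They also leave open which part of the difference between the core of compound 1 and the core of compound 3 goes with the higher number for compound 3.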